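Diaryl ether ureas: another terminal aryl variation

This account rests on a few compounds, and the source may have more. Where it says the series, first, only, none or still open, it means among the compounds named here.

Compound 3 `O=C(Nc1ccc(Oc2ccc(-c3nccs3)cc2)cc1)Nc1cc(C(F)(F)F)ccc1Cl` stands lowest of the three measured compounds in a functional assay on A549 cells (Homo sapiens) for inhibition, read by MTT assay and WST assay, with a stated time of 72 h, tested at 10 uM (on this read-out higher numbers stand for more inhibition of growth at the one concentration tested and lower numbers for less inhibition of growth), giving 75.5%. Compound 1 `O=C(Nc1ccc(Oc2ccc(-c3nccs3)cc2)cc1)Nc1ccc(Cl)c([N+](=O)[O-])c1` gives 77.1% and compound 2 `O=C(Nc1ccc(Oc2ccc(-c3nccs3)cc2)cc1)Nc1ccc(F)c(C(F)(F)F)c1` gives 76.4%. None of the three is separated from the others: a number 0.7 percentage points lower from compound 1 to compound 2 (within the scatter), a number 1.6 percentage points lower from compound 1 to compound 3 (within the scatter) and a number 0.9 percentage points lower from compound 2 to compound 3 (within the scatter) all lie within the scatter. The three terminal aryl groups tried so far on the amide-type nitrogen thus give numbers that cannot be told apart on this read-out.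

Compound 4 `O=C(Nc1ccc(Oc2ccc(-c3nccs3)cc2)cc1)Nc1cc(Br)cc(C(F)(F)F)c1` is the next variation at the same place: 3-bromo-5-(trifluoromethyl)phenyl in place of 2-chloro-5-(trifluoromethyl)phenyl on an amide-type nitrogen. All three measured steps bear on it, since each of them swaps one terminal aryl group for another on the amide-type nitrogen, and each of them stayed within the scatter. Among the measured compounds shown here, no measured compound carries a bromine on that ring, so the entering group itself is untested here. Given the three flat steps, the step from compound 3 to compound 4 is expected to stay within the scatter as well, with no direction beyond it, as a number 1.5 percentage points lower from compound 3 to compound 4 (within the scatter) shows. The estimate for compound 4 in this assay is 74%, with a range from 63% to 85%.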

Compound 4, percent growth inhibition at one concentration: 81.7%
The estimate for compound 4 lay 7.7 percentage points below the measured number; low and high end bracket the measured number.
By their numbers in this assay, from the lowest: compounds 3, 2, 1 and 4 (each within the scatter of the next).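

In this assay, the 3-bromo-5-(trifluoromethyl)phenyl group on the amide-type nitrogen remains within the scatter of all three earlier terminal aryl groups: a number 6.2 percentage points higher from compound 3 to compound 4 (within the scatter), a number 5.3 percentage points higher from compound 2 to compound 4 (within the scatter) and a number 4.6 percentage points higher from compound 1 to compound 4 (within the scatter). These steps are larger than those among compound 1, compound 2 and compound 3, but none is separated from the scatter, so the first bromine-bearing ring in this set does not separate compound 4 from the others on this read-out. Nothing measured here bears on why the four terminal aryl groups give numbers this close.

The terminal rings shown are all phenyl groups carrying chlorine, fluorine, bromine, nitro or trifluoromethyl, so it remains open whether a ring carrying an amine or a carboxylic acid would also stay within the scatter of these four compounds. Going by these compounds, with growth inhibition read at one concentration only, it also remains open whether compound 1, compound 2, compound 3 and compound 4 would separate across a full concentration series.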